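Adding a Methoxy Group to the Second Aryl Ring

A few compounds are considered here, and "the series" means these few. Any claim that something is new, unique, unknown or untested is made for them only; others in the source may bear on it.

Among the compounds with values here, compound 2 `COc1ccc(C(c2ccccc2)n2ccc3cc(/C(C)=C/C(=O)Nc4ccccc4OCCCC(=O)O)ccc32)cc1` is the stronger of the two compounds measured so far in an assay on Prostate gland for inhibition of steroid 5-alpha-reductase (Rattus norvegicus); on this read-out lower numbers stand for stronger inhibition and higher numbers for weaker inhibition: compound 2 gives 8.8 nM. Within the data shown here, its only measured neighbour, compound 1 `COc1ccc(Cn2ccc3cc(/C(C)=C/C(=O)Nc4ccccc4OCCCC(=O)O)ccc32)cc1`, gives 480 nM; the one recorded step, a 55-fold lower number from compound 1 to compound 2 (1.74 log units; beyond the scatter), reflects a phenyl in place of hydrogen on a saturated chain carbon bound to an aromatic carbon and an aromatic nitrogen, and it is large.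

Compound 3 `COc1ccc(C(c2ccc(OC)cc2)n2ccc3cc(/C(C)=C/C(=O)Nc4ccccc4OCCCC(=O)O)ccc32)cc1` is not yet measured. It differs from compound 2 by methoxy in place of hydrogen on an aromatic carbon. Among the measured compounds shown here, no measured step covers a change of this kind, so the large step from compound 1 to compound 2 does not bear on it directly; it only shows that changes at this part of the molecule can matter. With no guide for a methoxy addition, the expected step of a 1.1-fold lower number from compound 2 to compound 3 (0.04 log units; within the scatter) is small, within the scatter. Compound 3 is therefore estimated at 8 nM, with a range from 3 nM to 25 nM.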

Compound 3, half-maximal inhibitory concentration: 9.8 nM
The estimate for compound 3 lay 1.2-fold (0.09 log units) below the measured number; measured number inside the range.
By their numbers in this assay, from the lowest: compounds 2 and 3 (each within the scatter of the next); then compound 1.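

In this assay, the step of a 1.1-fold higher number from compound 2 to compound 3 (0.05 log units; within the scatter) shows that this position on the second aryl ring, para to a large group, accepts a methoxy group without a change that can be told from scatter. The large gain from putting a second aryl group on the saturated chain carbon is also not tied to plain phenyl: 4-methoxyphenyl in place of hydrogen there gives a 49-fold lower number from compound 1 to compound 3 (1.69 log units; beyond the scatter). No supporting data bear on why the added methoxy leaves the number where it was.

From the compounds shown here alone, it remains open whether a different group at this position, such as an amine, a carboxylic acid or a longer chain, would be accepted as well. Going by these compounds, all three compounds also carry a methoxy on the other aryl ring, so what that group contributes stays unknown.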